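Removing a Side Group from Compound 2

The source may report more compounds than this note shows. Statements on the series, on what has been measured and on what is new or still open speak of the compounds shown alone.

In a functional assay on KB cells (Homo sapiens) (on this read-out lower numbers stand for stronger inhibition and higher numbers for weaker inhibition), compound 1 (`CCOC(c1ccc(OC)cc1)c1ccc(C(C)C)cc(=O)c1O`) gives 1600 nM and compound 2 (`COc1ccc(C(c2ccc(C(C)C)cc(=O)c2O)c2ccc(C(C)C)cc(=O)c2O)cc1`) gives 1100 nM, two values within the usual scatter of each other. Compound 3 (`CC(C)C1=CC(=O)C(=O)/C(=C2/C=CC(C(C)C)=CC(O)=C2O)C=C1`) gives 9500 nM, a number beyond the scatter from those of the other two. Compound 2 therefore stands at the low end of the numbers, level with compound 1.

Compound 4 (`CC(C)c1ccc(Cc2ccc(C(C)C)cc(=O)c2O)c(O)c(=O)c1`) is compound 2 with a single change: hydrogen in place of 4-methoxyphenyl on a saturated chain carbon bound to two aromatic carbons. Going by the values given here, no measured pair shows this change alone. Compound 1 and compound 2 both carry the 4-methoxyphenyl group. Compound 3 lacks it and stands at 9500 nM, but it also differs from compound 2 in other ways, so it offers only a loose hint of a rise. In this assay a small upward step is expected, estimated as a 1.6-fold higher number from compound 2 to compound 4 (0.21 log units; within the scatter). For compound 4 the estimated value is 1800 nM, with an expected range of 600 nM to 6000 nM.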

Compound 4, half-maximal inhibitory concentration: < 900 nM
Compound 4: only a limit was reported; the forecaster's own chance of this, stated with the estimate: 5%; at least 2.0-fold (0.30 log units) between middle value and limit.
By their numbers in this assay, from the lowest: compounds 2 and 1 (each within the scatter of the next); then compound 3. At a limit, below all of these: compound 4.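

In this assay compound 4 carries a limit, not a number: the limit of < 900 nM in this assay, at which 1 of the 4 values shown sits. Read against compound 2, hydrogen in place of 4-methoxyphenyl on a saturated chain carbon bound to two aromatic carbons gives an at least 1.2-fold lower number from compound 2 to compound 4 (0.08 log units; that floor lies within the scatter), so the change brings no rise, although the guaranteed part of the step does not pass the scatter. Going by these compounds alone, this is the first comparison that changes this carbon alone, and it shows that the 4-methoxyphenyl group, carried by both compound 1 and compound 2, is not required there for a low number on this read-out.

As far as these compounds go, how far the true number of compound 4 lies under its limit stays unknown, so the real size of the step remains open. Also open, from the compounds shown here alone, is how a methyl group, an amine or a carboxylic acid on the same carbon would compare.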